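Replacing an Amide Side Chain: Compound 2 to Compound 4

The source may hold more compounds than are shown below. What is called first, only, known or untested is meant among the compounds shown, and "the series" means these compounds.

- compound 1 `Cc1cc(OCc2ccc(F)cc2F)c(Br)c(=O)n1Cc1cccc(CN(C)C)c1`: 50%
- compound 2 `Cc1cc(OCc2ccc(F)cc2F)c(Br)c(=O)n1Cc1ccc(C(=O)N(C)C)cc1`: 59%
- compound 3 `O=c1c(Br)c(OCc2ccc(F)cc2F)ccn1Cc1cccc(F)c1`: 48%

All three compounds were tested in an ADME assay on microsomes from liver (Homo sapiens) for metabolic stability, read by LC-MS, with a stated time of 45 min, tested at 2 uM; on this read-out lower numbers stand for a less stable compound and higher numbers for a more stable compound. There, compound 2 gives 59%, a number clear of compound 3 at 48% by more than the usual scatter. The gap between compound 2 and compound 1 at 50% stays within that scatter.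

The next compound, compound 4 `Cc1cc(OCc2ccc(F)cc2F)c(Br)c(=O)n1Cc1ccc(CNC(=O)CO)cc1`, has (((hydroxymethyl)carbonyl)amino)methyl in place of dimethylcarbamoyl on an aromatic carbon, para to a large group: (((hydroxymethyl)carbonyl)amino)methyl in place of dimethylcarbamoyl on an aromatic carbon. For the measured compounds named here, no pair of measured compounds differs in one place only, so the data offer no direct measure of what such a change does in this assay.

With so little to go on, no shift beyond the scatter is expected, and no direction is favoured. The expected change is a number 1 percentage points higher from compound 2 to compound 4 (within the scatter), an estimate that stays within the scatter. Compound 4 is estimated at 60%, with an expected range of 43% to 77%.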

Compound 4, percent of the compound remaining: 73%
Estimate against measurement, compound 4: 13 percentage points below; the measured number falls inside the stated range.
By their numbers in this assay, from the lowest: compounds 3, 1 and 2 (each within the scatter of the next, the first and the last beyond it); then compound 4.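

In this assay, for the compounds shown here, (((hydroxymethyl)carbonyl)amino)methyl in place of dimethylcarbamoyl on an aromatic carbon, para to a large group, gives a number 14 percentage points higher from compound 2 to compound 4 (beyond the scatter), the first step between compounds that differ in one place only. It shows that this position can move the read-out, and that a side chain with hydrogen-bond donors, where dimethylcarbamoyl has none, can go with a more stable compound. Nothing in the data shown accounts for the size or direction of this step.

With one pair, the hydroxyl and the amide hydrogen of the new chain cannot be told apart as the part that matters. On these data alone, it also remains open whether an acetamidomethyl chain without the hydroxyl, an aminomethyl group or a carboxylic acid at this place would give a similar number.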